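The source may hold more compounds than are shown below. What is called first, only, known or untested is meant among the compounds shown, and "the series" means these compounds.

Measured compounds:
Compound 1 `C=C1C(=O)[C@]23C[C@@]1(O)CC[C@H]2c1ccc(OS(=O)(=O)c2ccc(C)cc2)c(C)c1[C@@H]3Cn1cc(-c2ccccn2)nn1` — 2830 nM
Compound 2 `C=C1C(=O)[C@]23C[C@@]1(O)CC[C@H]2c1ccc(O)c(C)c1[C@@H]3Cn1cc(-c2ccccc2)nn1` — 1320 nM

In a functional assay on SMMC-7721 cells (Homo sapiens) for cytotoxicity, read by MTT assay, with a stated time of 4 days (on this read-out higher numbers stand for weaker inhibition and lower numbers for stronger inhibition), compound 2 gives 1320 nM, the lower of the two numbers recorded, while compound 1 gives 2830 nM, a gap that lies beyond the usual scatter of this assay. Going by the values given here, compound 1 differs from compound 2 in more than one place, so the two values show only that the pair is separated, not which part of the difference carries it.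

Compound 3 `C=C1C(=O)[C@]23C[C@@]1(O)CC[C@H]2c1ccc(O)c(C)c1[C@@H]3Cn1cc(-c2ccccn2)nn1` is the next compound, differing from compound 2 in a single place: pyridin-2-yl in place of phenyl on an aromatic carbon. Among the compounds with values here, no measured pair shows this change alone. Compound 2 with its phenyl gives the lower number and compound 1, which carries a pyridin-2-yl together with a further change, gives the higher one, so the step from compound 2 to compound 3 is expected to be small, either toward a weaker value or none beyond the scatter, and is estimated at a 1.3-fold higher number from compound 2 to compound 3 (0.11 log units; within the scatter). Compound 3 is therefore expected to give about 1700 nM, with a range of 750 nM to 3800 nM.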

Compound 3, half-maximal inhibitory concentration: 1270 nM
Estimate against measurement, compound 3: 1.3-fold (0.13 log units) above; the range from low to high includes it.
By their numbers in this assay, from the lowest: compounds 3 and 2 (each within the scatter of the next); then compound 1.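

In this assay the swap of phenyl for pyridin-2-yl now stands alone, and a 1.0-fold lower number from compound 2 to compound 3 (0.02 log units; within the scatter) shows that this change on the aromatic carbon of the five-membered ring leaves the two compounds within the scatter of each other. The other single change, hydrogen in place of (4-methylphenyl)sulfonyl on an oxygen on an aromatic ring, gives a 2.2-fold lower number from compound 1 to compound 3 (0.35 log units; beyond the scatter) and is a modest step beyond the scatter, so in this pair the group on that oxygen shows a difference where the ring nitrogen shows none. Nothing given here explains either step.

As far as these compounds go, whether a methyl or an acetyl on that oxygen would stand with compound 3 or with compound 1 remains open. So does the outcome of placing a pyridin-4-yl or a short alkyl chain where the phenyl and pyridin-2-yl sit.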